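Aryl swap from compound 3 to compound 4

The source may report more compounds than this note shows. Statements on the series, on what has been measured and on what is new or still open speak of the compounds shown alone.

In a functional assay on HeLa cells (Homo sapiens) for inhibition, read by sulforhodamine B assay (on this read-out higher numbers stand for weaker inhibition and lower numbers for stronger inhibition), compound 1 `O=C1C(Nc2ccc(I)cc2)=CC(=O)c2c1nc1n2[C@H]2OC[C@@H](O)[C@H]2OC1` gives 4010 nM, compound 2 `CCc1ccc(NC2=CC(=O)c3c(nc4n3[C@H]3OC[C@@H](O)[C@H]3OC4)C2=O)cc1` gives 6510 nM and compound 3 `O=C1C=C(Nc2ccccc2F)C(=O)c2c1nc1n2[C@H]2OC[C@@H](O)[C@H]2OC1` gives 5120 nM. Compound 3 therefore lies within the scatter of both others. Compound 4 `CCOc1ccc(NC2=CC(=O)c3nc4n(c3C2=O)[C@H]2OC[C@@H](O)[C@H]2OC4)cc1` carries 4-ethoxyphenyl in place of 2-fluorophenyl on an amine nitrogen. Within the data shown here, only one measured step bears on this change, a 1.6-fold higher number from compound 1 to compound 2 (0.21 log units; within the scatter), and it stays within the scatter. No step beyond the scatter, in either direction, is therefore expected in this assay. The expected step is a 1.1-fold higher number from compound 3 to compound 4 (0.03 log units; within the scatter). Compound 4 is estimated at 5500 nM, with an expected range of 2500 nM to 12000 nM.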

Compound 4, half-maximal inhibitory concentration: 3110 nM
Estimate against measurement, compound 4: 1.8-fold (0.25 log units) above; low and high end bracket the measured number.
By their numbers in this assay, from the lowest: compounds 4, 1, 3 and 2 (each within the scatter of the next, the first and the last beyond it).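

In this assay the change to 4-ethoxyphenyl on the amine nitrogen gives a 1.6-fold lower number from compound 3 to compound 4 (0.22 log units; within the scatter). The position therefore accepts an aryl group of 9 heavy atoms in place of one of 7, now with a hydrogen-bond acceptor and without fluorine, and no step beyond the scatter appears. Both steps read so far on this aryl group stay within the scatter.

Open, from the compounds shown here alone, is whether an aryl group carrying a carboxylic acid or a basic amine, or a saturated cyclohexyl group on this nitrogen, would move the number beyond the scatter. No supporting data offer an explanation for this result.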